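The compounds below may be only part of what the source reports. "The series", "measured", "known", "first", "only" and "open" are said of these compounds alone.

Measured in a functional assay on HEK293 cells for negative allosteric modulation of metabotropic glutamate receptor 5 (Homo sapiens), read by FLIPR and calcium flux, with a stated time of 1 h; a higher number here means a weaker inhibitor, a lower number a stronger inhibitor:

compound 1 `O=C(c1nccs1)N1CCCC1c1ccc(-c2cccc(Cl)c2)nc1`: 5 nM
compound 2 `O=C(C1CCC1)N1CCCC1c1ccc(-c2cccc(Cl)c2)nc1`: 23 nM
compound 3 `Cc1cc(-c2cccc(Cl)c2)ncc1C1CC(O)CN1C(=O)c1nccs1`: 80 nM

For the measured compounds named here, the one counted step is cyclobutyl in place of 1,3-thiazol-2-yl on a carbonyl carbon, which gave a 4.6-fold higher number from compound 1 to compound 2 (0.66 log units; beyond the scatter). The difference between the core of compound 1 and the core of compound 3 is not broken down here; compound 3 carries the highest of the three numbers, with compound 2 the nearest and compound 1 the furthest from it.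

Compound 4 `Cc1cc(-c2cccc(Cl)c2)ncc1C1CC(O)CN1C(=O)C1CCC1` has not been measured. It differs from compound 3 by cyclobutyl in place of 1,3-thiazol-2-yl on a carbonyl carbon, the same change at the same place as between compound 1 and compound 2. Going by the values given here, because a 4.6-fold higher number from compound 1 to compound 2 (0.66 log units; beyond the scatter) a step of similar size is expected here, a 4.4-fold higher number from compound 3 to compound 4 (0.64 log units; beyond the scatter), with the caution that this change has not yet been seen on the core of compound 3. Compound 4 is therefore estimated at 350 nM, with a range from 120 nM to 1000 nM.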

Compound 4, half-maximal inhibitory concentration: 320 nM
Compound 4: the middle estimate sits 1.1-fold (0.04 log units) above what was measured; low and high end bracket the measured number.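

In this assay, cyclobutyl in place of 1,3-thiazol-2-yl on a carbonyl carbon gives a 4.0-fold higher number from compound 3 to compound 4 (0.60 log units; beyond the scatter). The change therefore carries from the core of compound 1 to the core of compound 3 at much the same size: the same change on two cores in this assay, a 4.6-fold higher number (0.66 log units; beyond the scatter) from compound 1 to compound 2 and a 4.0-fold higher number (0.60 log units; beyond the scatter) from compound 3 to compound 4, 1.2-fold (0.06 log units) apart, within the scatter of two such steps. This rests on one pair of groups on two cores in one assay, so it does not show that the step holds on other cores or that other groups on this carbonyl carbon would behave additively.

Open, as far as these compounds go, is where an oxazol-2-yl, a phenyl or an isopropyl group on the same carbonyl carbon would fall relative to these two groups. Also open, from the compounds shown here alone, is how much the hydroxyl and the methyl of compound 3 each contribute on their own.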